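A Second Fluorine Position on the Shared Core

A few compounds are considered here, and "the series" means these few. Any claim that something is new, unique, unknown or untested is made for them only; others in the source may bear on it.

Compound 1, `CC(C)(C)OC(=O)N1CCC(CCOC(=O)N2CCc3cc(S(C)(=O)=O)ccc32)CC1`: 68 nM
Compound 2, `CC(C)(C)OC(=O)N1CCC(CCOC(=O)N2CCc3c2ccc(S(C)(=O)=O)c3F)CC1`: 25 nM

Among these two numbers from a functional assay on CHO cells for agonist activity at Glucose-dependent insulinotropic receptor (Homo sapiens), read by a luciferase reporter and cAMP accumulation, with a stated time of 2 h (a lower number here means that less compound is needed, a higher number that more compound is needed for the effect), compound 1 stands highest, meaning it needs the most compound. For the measured compounds named here, the only measured step is a 2.7-fold lower number from compound 1 to compound 2 (0.43 log units; beyond the scatter), a modest change beyond the scatter. Compound 3, `CC(C)(C)OC(=O)N1CCC(CCOC(=O)N2CCc3cc(S(C)(=O)=O)cc(F)c32)CC1`, differs from compound 1 by fluoro in place of hydrogen on an aromatic carbon. This is the same kind of change as the measured step, but at a different place on the core, so a modest lowering or no step beyond the scatter is expected. The expected step is a 1.7-fold lower number from compound 1 to compound 3 (0.23 log units; within the scatter). Compound 3 is estimated at 40 nM, between 15 nM and 120 nM.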

Compound 3, half-maximal effective concentration: 25 nM
For compound 3 the middle estimate is 1.6-fold (0.20 log units) above the measured one; low and high end bracket the measured number.
By their numbers in this assay, from the lowest: compounds 2 and 3 (each within the scatter of the next); then compound 1.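

In this assay, fluoro in place of hydrogen on an aromatic carbon meta to a methylsulfonyl group gives a 2.7-fold lower number from compound 1 to compound 3 (0.43 log units; beyond the scatter), so a second place on the shared core also responds to this change. Compound 2, with its fluoro at another place, and compound 3 both print 25 nM, so the two placements cannot be told apart by this number. Nothing measured here gives a reason for the step. From the compounds shown here alone, whether chloro or methoxy at this place would act like fluoro stays open, as does the result of two fluoro groups on one core.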